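Replacing the Ester Amide of Compound 2

This account rests on a few compounds, and the source may have more. Where it says the series, first, only, none or still open, it means among the compounds named here.

compound 1 `CCN(CC)CCNC(=O)c1ccc(C(CC)(CC)c2ccc(OCCC(O)(CC)CC)c(C)c2)n1CC`: 550 nM
compound 2 `CCOC(=O)CN(C)C(=O)c1ccc(C(CC)(CC)c2ccc(OCCC(O)(CC)CC)c(C)c2)n1CC`: 3210 nM

In a functional assay on MCF7 cells (Homo sapiens) for antiproliferative activity, read by MTT assay, with a stated time of 48 h (a lower number here means a stronger inhibitor, a higher number a weaker inhibitor), compound 2 gives 3210 nM, the higher of the two numbers, and compound 1 gives 550 nM. The next compound, compound 3 `CCC(C)C(CO)NC(=O)c1ccc(C(CC)(CC)c2ccc(OCCC(O)(CC)CC)c(C)c2)n1CC`, keeps the shared core and differs from compound 2 on a carbonyl carbon: (1-(hydroxymethyl)-2-methylbutyl)amino in place of ((ethoxycarbonyl)methyl)(methyl)amino on a carbonyl carbon. In words, (1-(hydroxymethyl)-2-methylbutyl)amino stands in place of ((ethoxycarbonyl)methyl)(methyl)amino.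

Among the compounds with values here, only one measured step bears on this change: a 5.8-fold higher number from compound 1 to compound 2 (0.77 log units; beyond the scatter). It was modest and took place on the same carbonyl carbon, so it shows that a change there can move the number beyond the scatter. It is a single step, however, and the group entering compound 3 appears in neither measured compound. Compound 3 shares with compound 1 the amide hydrogen that compound 2 lacks, so a small move toward a lower number is expected in this assay. The step expected is a 1.7-fold lower number from compound 2 to compound 3 (0.23 log units; within the scatter). For compound 3 the estimated value is 1900 nM, with an expected range from 600 nM to 6000 nM.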

Compound 3, half-maximal inhibitory concentration: 29100 nM
For compound 3 the middle estimate is 15-fold (1.19 log units) below the measured one; measured number outside the range, above it.
By their numbers in this assay, from the lowest: compound 1; then compound 2; then compound 3.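

In this assay, restoring the amide hydrogen did not lower the number: (1-(hydroxymethyl)-2-methylbutyl)amino in place of ((ethoxycarbonyl)methyl)(methyl)amino gives a 9.1-fold higher number from compound 2 to compound 3 (0.96 log units; beyond the scatter). The size of the 1-(hydroxymethyl)-2-methylbutyl group's departure from the 2-(diethylamino)ethyl group on the amide-type nitrogen is larger still, at a 53-fold higher number from compound 1 to compound 3 (1.72 log units; beyond the scatter), so the two compounds that carry the amide hydrogen lie furthest apart of the three, and that hydrogen alone does not set the number at this position. Nothing available accounts for this result, and the reason for the rise remains unknown.

The compounds shown leave open which part of the entering group goes with the higher number, the hydroxymethyl or the branched 2-methylbutyl chain, for these two parts enter together and a simple 2-hydroxyethyl group or an unsubstituted 2-methylbutyl group on the same nitrogen would separate them. They also leave open whether the diethylamino end of compound 1 is what keeps its number low, a question that a 2-(dimethylamino)ethyl group, a morpholine or a plain butyl chain on that nitrogen would address.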